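Diethylamino in place of pyrrolidin-1-yl on compound 2

A few compounds are considered here, and "the series" means these few. Any claim that something is new, unique, unknown or untested is made for them only; others in the source may bear on it.

In a functional assay on A549 cells (Homo sapiens) for inhibition (a higher number here means a weaker inhibitor, a lower number a stronger inhibitor), compound 3 `CN(C(=O)CC(CC(=O)NCCN1CCCC1)c1ccc(Cl)cc1)C1Cc2ccccc2C1` gives 56000 nM. Compound 2 `CN(C(=O)CC(CC(=O)NCCN1CCCC1)c1ccccc1)C1Cc2ccccc2C1` reads > 100000 nM, which is a limit of the assay and not a number. Compound 4 `CCN(CC)CCNC(=O)CC(CC(=O)N(C)C1Cc2ccccc2C1)c1ccccc1` differs from compound 2 by one change on a saturated chain carbon, two bonds along the chain from an amide-type nitrogen: diethylamino in place of pyrrolidin-1-yl on a saturated chain carbon, two bonds along the chain from an amide-type nitrogen.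

Going by the values given here, the only measured step, an at least 1.7-fold lower number from compound 2 to compound 3 (0.25 log units; that floor lies within the scatter), is a chloro in place of hydrogen on an aromatic carbon, so no measured step tests this exchange directly. Compound 1 `CCN(CC)CCNC(=O)CC(CC(=O)NC1Cc2ccccc2C1)c1ccccc1`, which also carries 2-(diethylamino)ethyl, gives 82400 nM, and this value guides the expectation of no step beyond the scatter in this assay. The expected change is an at least 1.1-fold lower number from compound 2 to compound 4 (0.04 log units; that floor lies within the scatter). For compound 4 the estimate is 90000 nM, with an expected range of 50000 nM to 160000 nM.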

Compound 4, half-maximal inhibitory concentration: > 100000 nM
Compound 4 was reported as a limit; the forecaster's own chance of this, stated with the estimate: 45%; middle value at least 1.1-fold (0.04 log units) from the limit.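

The step from pyrrolidin-1-yl to diethylamino cannot be read in this assay because compound 2 and compound 4 each end at a limit of the assay and not at a number: the limit of > 100000 nM in this assay, at which 2 of the 4 values shown sit.

Methyl in place of hydrogen on the amide-type nitrogen gives an at least 1.2-fold higher number from compound 1 to compound 4 (0.08 log units; that floor lies within the scatter), so this pair neither shows nor excludes a real loss.

Open, going by these compounds, is whether diethylamino and pyrrolidin-1-yl differ at all on a core that reads inside the range of this assay. Also open, on these data alone, is whether morpholin-4-yl, or a longer chain to the amine, would read inside it.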